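This account rests on a few compounds, and the source may have more. Where it says the series, first, only, none or still open, it means among the compounds named here.

Measured in a functional assay on MCF7 cells (Homo sapiens) for inhibition, read by MTT assay, with a stated time of 48 h; a higher number here means a weaker inhibitor, a lower number a stronger inhibitor:
Compound 1 `CCOC(=O)C1=C(NN=C(C(C)=O)C(C)=O)Nc2[nH]nc(C)c2C1c1ccc(N(C)C)cc1` gives 9740 nM.
Compound 2 `CCOC(=O)C1=C(N/C=N/c2ccc([N+](=O)[O-])cc2)Nc2[nH]nc(C)c2C1c1ccc(N(C)C)cc1` gives 58600 nM.
Compound 3 `CCOC(=O)C1=C(N/N=C(/C(=O)Br)c2ccc(Br)cc2)Nc2[nH]nc(C)c2C1c1ccc(N(C)C)cc1` gives 61300 nM.

Compound 3 has the highest number of the three; its gap to compound 2 lies within the scatter, while a 6.3-fold higher number from compound 1 to compound 3 (0.80 log units; beyond the scatter). Compound 4 `CCOC(=O)C1=C(N/N=C(/Cl)c2ccc([N+](=O)[O-])cc2)Nc2[nH]nc(C)c2C1c1ccc(N(C)C)cc1` has not been measured. It differs from compound 3 in one place: a group of 12 heavy atoms (7 carbon, 2 nitrogen, 2 oxygen, 1 chlorine; one six-membered aromatic ring of carbon only) in place of a group of 12 heavy atoms (8 carbon, 1 nitrogen, 1 oxygen, 2 bromine; one six-membered aromatic ring of carbon only), on an amine nitrogen. The step that bears most on this is a 1.0-fold higher number from compound 2 to compound 3 (0.02 log units; within the scatter), where one ring-bearing group replaced another on the same amine nitrogen and the two numbers stayed within the scatter of each other. Among the compounds with values here, the only large steps, a 6.0-fold higher number from compound 1 to compound 2 (0.78 log units; beyond the scatter) and a 6.3-fold higher number from compound 1 to compound 3 (0.80 log units; beyond the scatter), accompanied exchange of the ring-free group of compound 1 for ring-bearing ones, and compound 4 keeps a ring-bearing group. Compound 4 is therefore expected to show no step beyond the scatter: a 1.1-fold lower number from compound 3 to compound 4 (0.05 log units; within the scatter). The estimated value of compound 4 is 55000 nM, within 20000 nM to 150000 nM.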

Compound 4, half-maximal inhibitory concentration: 52700 nM
Compound 4: the middle estimate sits 1.0-fold (0.02 log units) above what was measured, within the range that was stated.
By their numbers in this assay, from the lowest: compound 1; then compounds 4, 2 and 3 (each within the scatter of the next).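

On the amine nitrogen, a third ring-bearing group leaves the number where the other two stood (a 1.2-fold lower number from compound 3 to compound 4 (0.07 log units; within the scatter)) (a 1.1-fold lower number from compound 2 to compound 4 (0.05 log units; within the scatter)). The ring-free group of compound 1 still stands apart from this new group (a 5.4-fold higher number from compound 1 to compound 4 (0.73 log units; beyond the scatter)), so compounds 2, 3 and 4 now form one level despite their different atoms. Open, going by these compounds, is whether the ring itself goes with this gap, or something else in the groups: a plain alkyl chain, an amine or a carboxylic acid on this nitrogen could help separate the two. No measured evidence here explains the gap.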